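Benzyl Substitution on the Amide Nitrogen of Compound 3

A few compounds are considered here, and "the series" means these few. Any claim that something is new, unique, unknown or untested is made for them only; others in the source may bear on it.

Measured compounds:
Compound 1, `COC(=O)/C=C/c1cccc(N(Cc2ccc(-c3cccc(Cl)c3)cc2)C(=O)C2CCCCC2)c1`: 94 nM
Compound 2, `COC(=O)/C=C/c1cccc(N(Cc2ccc(-c3cccc(C)c3)cc2)C(=O)C(C)C)c1`: 163 nM
Compound 3, `COC(=O)/C=C/c1cccc(NC(=O)C2CCCCC2)c1`: > 1000 nM

All three share a cinnamate-bearing anilide core. In an assay on isolated protein with Bile acid receptor (Homo sapiens) as the target (on this read-out lower numbers stand for an effect already at smaller amounts and higher numbers for an effect only at larger amounts of compound), compound 1 gives 94 nM. Compound 2, which carries a different branched acyl group and a methyl-substituted biaryl benzyl group on the same nitrogen, gives 163 nM, a value within the usual scatter of compound 1. Compound 3 stands apart: for it the assay returned only a limit, > 1000 nM, so no number is known for it, and it sits at the limit of > 1000 nM in this assay, at which 1 of the 3 values shown sits. Compound 3 is the only one of the three that carries a hydrogen rather than a benzyl-type group on the amide-type nitrogen.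

Compound 4, `COC(=O)/C=C/c1cccc(N(Cc2ccccc2Br)C(=O)C2CCCCC2)c1`, differs from compound 3 by 2-bromobenzyl in place of hydrogen on an amide-type nitrogen. Within the data shown here, no directly comparable pair among the measured compounds gives the size of such a step. Still, compound 1 and compound 2, each with a substituted benzyl group on that nitrogen, give values well below the limit shown for compound 3, so a step toward lower numbers beyond the scatter is expected from compound 3 to compound 4, of about an at least 2.0-fold lower number from compound 3 to compound 4 (0.30 log units; that floor lies within the scatter). Compound 4 is therefore estimated at 500 nM, with a likely range from 120 nM to 2500 nM.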

Compound 4, half-maximal effective concentration: > 1000 nM
Compound 4: no number, only a limit; the forecaster's own chance of this, stated with the estimate: 30%; middle value at least 2.0-fold (0.30 log units) from the limit.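

In this assay, among these compounds, compound 3 and compound 4 each return only a limit and no number, so no step between the two compounds can be read: the limit of > 1000 nM in this assay, at which 2 of the 4 values shown sit. The compounds shown leave open how large a change, if any, 2-bromobenzyl in place of hydrogen on the amide-type nitrogen brings.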